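The source may hold more compounds than are shown below. What is called first, only, known or untested is meant among the compounds shown, and "the series" means these compounds.

Values measured so far in a functional assay on HeLa cells (Homo sapiens) for inhibition, read by sulforhodamine B assay (on this read-out higher numbers stand for weaker inhibition and lower numbers for stronger inhibition), are these.
- Compound 1 `CCCc1ccc(NC2=CC(=O)c3nc4n(c3C2=O)[C@H]2OC[C@@H](O)[C@H]2OC4)cc1` gives 4990 nM as a number
- Compound 2 `O=C1C(Nc2ccccc2)=CC(=O)c2c1nc1n2[C@H]2OC[C@@H](O)[C@H]2OC1` gives > 8000 nM as a limit of the assay, not a number
- Compound 3 `O=C1C=C(N2CCC2)C(=O)c2c1nc1n2[C@H]2OC[C@@H](O)[C@H]2OC1` gives > 16000 nM as a limit of the assay, not a number

Compound 2 has no number on this read-out and stands only at its limit (> 8000 nM). Of the three compounds, only compound 1 (4990 nM) has a measured number.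

The next compound is compound 4 `CCc1ccc(NC2=CC(=O)c3c(nc4n3[C@H]3OC[C@@H](O)[C@H]3OC4)C2=O)cc1`, where ethyl takes the place of hydrogen on an aromatic carbon of compound 2, para to a large group, taking phenyl to 4-ethylphenyl (ethyl in place of hydrogen on an aromatic carbon). Within the data shown here, no measured pair isolates this change, so the expectation is loose. It rests on compound 1 (4990 nM), which carries a propyl chain on its aromatic ring and still gives a number. A modest move toward stronger inhibition in this assay is therefore expected, and the estimated step (an at least 1.4-fold lower number from compound 2 to compound 4 (0.16 log units; that floor lies within the scatter)) may not clear the scatter by much. A reading that again returns only a limit would not be surprising. The estimated value for compound 4 is 5500 nM with an expected range (2000 nM to 15000 nM).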

Compound 4, half-maximal inhibitory concentration: 6510 nM
The estimate for compound 4 lay 1.2-fold (0.07 log units) below the measured number, within the range that was stated.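

In this assay, among these compounds, the change from phenyl to 4-ethylphenyl is the first single change that can be read on this ring, with an at least 1.2-fold lower number from compound 2 to compound 4 (0.08 log units; that floor lies within the scatter). The full size of this step cannot be read, and its floor alone does not separate the two compounds, because compound 2 stands only at a limit of the assay and not at a number: the limit of > 8000 nM in this assay, at which 1 of the 4 values shown sits. The ethyl group of compound 4 also shows that a number on this read-out is not tied to the propyl chain of compound 1 alone.

From the compounds shown here alone, a methyl group, a butyl chain, a carboxylic acid or an amine at the same place on the ring remains open, and with it whether a number appears for other groups there. Two chains do not settle any dependence on chain length in this assay, where compound 1 gives 4990 nM and compound 4 gives 6510 nM, and the series shown does not yet tell whether a further ethyl-type change would move the number.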